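The source may hold more compounds than are shown below. What is called first, only, known or untested is meant among the compounds shown, and "the series" means these compounds.

- Compound 1 `CC(C)[C@@H](C(=O)N1CCC[C@H]1C(=O)N[C@@H](CCCNC(=N)N)C(=O)CF)N(C)C(=O)OCc1ccccc1`: > 20000 nM
- Compound 2 `CC(C)[C@H](NC(=O)c1ccc(Br)cc1)C(=O)N1CCC[C@H]1C(=O)N[C@@H](CCCNC(=N)N)C(=O)CF`: 130 nM
- Compound 3 `CC(C)c1ccc(C(=O)N[C@H](C(=O)N2CCC[C@H]2C(=O)N[C@@H](CCCNC(=N)N)C(=O)CF)C(C)C)cc1`: 270 nM

These values come from a functional assay on OCI-Ly3 cells (Homo sapiens) for inhibition, read by CellTiter-Glo, with stated times of 48 h and 96 h; on this read-out lower numbers stand for stronger inhibition of growth and higher numbers for weaker inhibition of growth. The entry for compound 1, > 20000 nM, is a limit of the assay and not a number. Among the measured compounds shown here, compound 3, at 270 nM, has the higher of the two actual numbers, and the only comparison between numbers is a 2.1-fold higher number from compound 2 to compound 3 (0.32 log units; beyond the scatter).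

Compound 4 `CC(C)[C@H](NC(=O)Nc1ccc(Cl)cc1)C(=O)N1CCC[C@H]1C(=O)N[C@@H](CCCNC(=N)N)C(=O)CF` differs from compound 3 by (4-chlorophenyl)amino in place of 4-isopropylphenyl on a carbonyl carbon. In words, ((4-isopropylphenyl)carbonyl)amino becomes ((4-chlorophenyl)carbamoyl)amino.

The large steps, an at least 150-fold lower number from compound 1 to compound 2 (2.18 log units; beyond the scatter) and an at least 74-fold lower number from compound 1 to compound 3 (1.86 log units; beyond the scatter), both replace (benzyloxycarbonyl)(methyl)amino, so they bear on this change only loosely. The modest 2.1-fold higher number from compound 2 to compound 3 (0.32 log units; beyond the scatter) is the closest guide, as it alters only the group on the aromatic ring. For the measured compounds named here, no measured step tests the new carbamoyl link, so only a small shift in this assay is expected, slightly downward if anything.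

The estimated change is a 1.4-fold lower number from compound 3 to compound 4 (0.13 log units; within the scatter). Compound 4 is expected at 200 nM, with an estimated range from 60 nM to 700 nM.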

Compound 4, concentration for 50% growth inhibition: 780 nM
Compound 4: middle estimate off by 3.9-fold (0.59 log units), on the low side; measured number above the stated range.
By their numbers in this assay, from the lowest: compound 2; then compound 3; then compound 4. At a limit, above all of these: compound 1.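

At this position the carbamoyl link with a 4-chlorophenyl group keeps growth inhibition but gives no gain over the two aryl amides, with a 2.9-fold higher number from compound 3 to compound 4 (0.46 log units; beyond the scatter) and a 6.0-fold higher number from compound 2 to compound 4 (0.78 log units; beyond the scatter). Each of these steps changes the link and the ring substituent together, so neither can be assigned to one alone. Compound 1 stands at a limit of the assay and not at a number, so an at least 25-fold lower number from compound 1 to compound 4 (1.40 log units; beyond the scatter) gives only a bound on how much of the earlier gain the carbamoyl link retains: the limit of > 20000 nM in this assay, at which 1 of the 4 values shown sits.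

Going by these compounds, it remains open how a 4-chlorobenzoyl group would read here, which would separate the chloro substituent from the added amino nitrogen. Also open, on these data alone, is how (4-bromophenyl)amino or (4-isopropylphenyl)amino would behave on the same carbonyl carbon.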